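This account rests on a few compounds, and the source may have more. Where it says the series, first, only, none or still open, it means among the compounds named here.

Of the compounds shown here, three built on the shared core have been tested in an assay (Cavia porcellus) for inhibition of Polyunsaturated fatty acid 5-lipoxygenase (Homo sapiens); a higher number here means a weaker inhibitor, a lower number a stronger inhibitor. Compound 1 `NC(=O)N(O)CC1=Cc2cc(OCC3CCCCC3)ccc2OC1` gives 1390 nM, and compound 2 `CC(C)(C)c1ccc(Oc2ccc3c(c2)C=C(CN(O)C(N)=O)CO3)cc1` gives 1900 nM. Compound 3 `NC(=S)N(O)CC1=Cc2cc(Oc3ccccc3)ccc2OC1` gives 200 nM, the lowest of the three numbers, and its separation from each of compound 1 and compound 2 lies beyond the usual scatter. Compound 4 `C=CCNC(=O)N(O)CC1=Cc2cc(Oc3ccccc3)ccc2OC1` has not yet been measured. It differs from compound 3 by a group of 6 heavy atoms (4 carbon, 1 nitrogen, 1 oxygen; no ring) in place of a group of 3 heavy atoms (1 carbon, 1 nitrogen, 1 sulfur; no ring), on an amine nitrogen, so the thiourea becomes an allyl-substituted urea. Compound 1 and compound 2, which also carry a urea rather than a thiourea, show higher numbers than compound 3, so the step from compound 3 to compound 4 is expected to go upward, by about a 3.5-fold higher number from compound 3 to compound 4 (0.54 log units; beyond the scatter). Compound 4 is estimated at 700 nM, within a range of 250 nM to 2000 nM.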

Compound 4, half-maximal inhibitory concentration: 44 nM
For compound 4 the middle estimate is 16-fold (1.20 log units) above the measured one; the measured number lies below the stated range.
By their numbers in this assay, from the lowest: compound 4; then compound 3; then compounds 1 and 2 (each within the scatter of the next).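

At the amine nitrogen whose other neighbours are oxygen and a saturated chain carbon, swapping the thiourea group for allylcarbamoyl gives a 4.5-fold lower number from compound 3 to compound 4 (0.66 log units; beyond the scatter) in this assay. So this position accepts the larger group, but sulfur gives way to oxygen and the allyl chain arrives in the same step, and the two changes cannot be told apart. No supporting measurement accounts for the drop.

Open, going by these compounds, is how an allylthiocarbamoyl group, keeping the sulfur with the allyl chain, would compare. Also open, on these data alone, is whether a saturated propyl chain or a longer chain would serve as well as allyl.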